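Ethyl in place of methyl on the carbamoyl nitrogen

The compounds below may be only part of what the source reports. "The series", "measured", "known", "first", "only" and "open" are said of these compounds alone.

Measured so far:
compound 1, `CNC(=O)c1cc(Oc2cccc(NC(=S)Nc3ccc(Cl)cc3)c2)ccn1`: 39400 nM
compound 2, `CNC(=O)c1cc(Oc2cccc(NC(=S)Nc3ccc(F)c(F)c3)c2)ccn1`: 30300 nM

In a functional assay on HCT-116 cells (Homo sapiens) for cytotoxicity, read by MTT assay, with a stated time of 48 h (a higher number here means a weaker inhibitor, a lower number a stronger inhibitor), compound 2 gives the lowest of the two numbers measured, with compound 1 nearest: a 1.3-fold lower number from compound 1 to compound 2 (0.11 log units; within the scatter). Compound 3, `CCNC(=O)c1cc(Oc2cccc(NC(=S)Nc3ccc(F)c(F)c3)c2)ccn1`, differs from compound 2 in one place: methyl in place of hydrogen on a saturated chain carbon bound to an amide-type nitrogen. Among the measured compounds shown here, no measured step touches the carbamoyl nitrogen; the only step measured, from compound 1 to compound 2, concerns the aryl on the thiourea and lies within the scatter. Nothing therefore points to a shift beyond the scatter, in either direction. Compound 3 is expected to give 30000 nM, within 12000 nM to 75000 nM, an expected step of a 1.0-fold lower number from compound 2 to compound 3 (0.00 log units; within the scatter).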

Compound 3, half-maximal inhibitory concentration: 30300 nM
The estimate for compound 3 lay 1.0-fold (0.00 log units) below the measured number, within the range that was stated.
By their numbers in this assay, from the lowest: compounds 2, 3 and 1 (each within the scatter of the next).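

In this assay, among the compounds shown here, ethyl in place of methyl on the carbamoyl nitrogen gives no change at the digits printed from compound 2 to compound 3 (within the scatter), the first reading at this position, since the earlier step concerned only the aryl on the thiourea. With the 3,4-difluorophenyl group in place, this position therefore accepts the methylcarbamoyl to ethylcarbamoyl exchange without a shift beyond the scatter. No measurement at hand offers an explanation for this result.

On these data alone, whether a longer chain such as propyl, or a carboxylic acid in place of the carbamoyl group, would read alike remains open. So does whether ethyl reads alike alongside the 4-chlorophenyl group of compound 1.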